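A few compounds are considered here, and "the series" means these few. Any claim that something is new, unique, unknown or untested is made for them only; others in the source may bear on it.

Measured in a physicochemical assay for solubility, with a stated time of 3 days, at pH 7; on this read-out lower numbers stand for lower solubility and higher numbers for higher solubility:
Compound 1 `COc1ccc(CN2CCCC(COc3ccc(-c4nc5cc(C(N)=O)ccc5[nH]4)cc3)C2)cc1`: "not determined" (no result reported)
Compound 2 `NC(=O)c1ccc2[nH]c(-c3ccc(OCCC4CCCCN4Cc4ccccc4)cc3)nc2c1`: 155000 nM

For the measured compounds named here, compound 2, at 155000 nM, holds the only number so far. Compound 1 has no result. Compound 3 `NC(=O)c1ccc2[nH]c(-c3ccc(OCCC4CCCCN4C(=O)c4ccccc4)cc3)nc2c1` differs from compound 2 in one place: benzoyl in place of benzyl on an amine nitrogen in a ring. Going by the values given here, no measured pair shows what such a change does in this assay, so the expectation is a judgement: a moderate fall, somewhat beyond the usual scatter. The expected change is a 3.9-fold lower number from compound 2 to compound 3 (0.59 log units; beyond the scatter). For compound 3 the estimated value is 40000 nM, with an expected range from 8000 nM to 150000 nM.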

Compound 3, solubility: 18000 nM
Estimate against measurement, compound 3: 2.2-fold (0.35 log units) above; measured number inside the range.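

In this assay, for the compounds shown here, benzoyl in place of benzyl on the amine nitrogen in the ring gives an 8.6-fold lower number from compound 2 to compound 3 (0.94 log units; beyond the scatter) and so provides the first measured step at this position. The group on this nitrogen therefore matters to the read-out, and the size of the step lies beyond the usual scatter. Nothing measured here gives a reason for the fall.

Only these two groups on the nitrogen can be compared. On these data alone, how an acetyl group, a methyl group or a plain hydrogen there would compare remains open.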